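The source may report more compounds than this note shows. Statements on the series, on what has been measured and on what is new or still open speak of the compounds shown alone.

Compound 1 `CCOC(=O)/C=C/[C@H]1C[C@@H](O)[C@@H](O)C1` was tested in an ADME assay on S2 cells (Drosophila melanogaster) for cytotoxicity, read by MTT assay; on this read-out lower numbers stand for an effect already at smaller amounts and higher numbers for an effect only at larger amounts of compound. In this assay compound 1 gives only the assay limit of > 350000 nM, which is a limit and not a number. Compound 2 `CCCCCCOC(=O)/C=C/[C@H]1C[C@@H](O)[C@@H](O)C1` likewise gives only the limit of > 350000 nM in this assay. The step that the two limits leave unreadable from compound 1 to compound 2 is thus not readable; both values rest at the limit of > 350000 nM in this assay, at which 2 of the 2 values shown sit, so no step size is available to lean on. Compound 3 `CN(C)C(=O)/C=C/[C@H]1C[C@@H](O)[C@@H](O)C1` differs from compound 1 by dimethylamino in place of ethoxy on a carbonyl carbon. For the measured compounds named here, no measured step resembles this change. Compound 3 is expected to remain near the limit, a step that the limit leaves unreadable from compound 1 to compound 3. The estimate for compound 3 is 400000 nM, between 150000 nM and 1000000 nM.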

Compound 3, half-maximal effective concentration: > 250000 nM
Compound 3 was reported as a limit; the forecaster's own chance of this, stated with the estimate: 85%; the middle value lies beyond the limit too.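

Compound 1 and compound 3 each give only a limit, not a number, in this assay, and the step between them cannot be read. The compounds shown leave open at what concentration, if any, an effect would appear.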